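The compounds below may be only part of what the source reports. "The series", "measured", "known", "first", "only" and "open" are said of these compounds alone.

Measured compounds:

- compound 1 `Clc1ccc(-c2cc(-c3cccnc3)nc(-c3cccs3)c2)o1`: 14600 nM
- compound 2 `Clc1ccc(-c2cc(-c3ccco3)nc(-c3cccs3)c2)o1`: 18800 nM
- compound 3 `Clc1ccc(-c2cc(-c3cccs3)nc(-c3ccccc3Cl)c2)o1`: 18500 nM

The three compounds share a core and differ only in the aromatic group attached at one carbon of that core. In a functional assay on HeLa cells (Homo sapiens) for cytotoxicity, in the presence of a further agent that is not named here (on this read-out higher numbers stand for weaker inhibition and lower numbers for stronger inhibition), compound 3 gives 18500 nM, the second highest of the three numbers, but every gap between these compounds lies within the scatter: a 1.3-fold higher number from compound 1 to compound 2 (0.11 log units; within the scatter), a 1.3-fold higher number from compound 1 to compound 3 (0.10 log units; within the scatter) and a 1.0-fold lower number from compound 2 to compound 3 (0.01 log units; within the scatter). Swapping pyridin-3-yl, furan-2-yl or 2-chlorophenyl at this place has therefore not changed the read-out in a way that can be told from noise.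

Compound 4 `Clc1cccc(-c2cc(-c3ccc(Cl)o3)cc(-c3cccs3)n2)c1` is the next step: 3-chlorophenyl in place of 2-chlorophenyl on an aromatic carbon. Going by the values given here, no measured pair bears directly on moving the chlorine from one position of the phenyl ring to another. The nearest guidance is that far larger exchanges of the whole group at this carbon stayed within the scatter, so no step beyond the scatter is expected here either, and compound 4 is expected to give 18500 nM in this assay, in a range from 9000 nM to 38000 nM. The expected step is no change at the digits printed from compound 3 to compound 4 (within the scatter).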

Compound 4, half-maximal inhibitory concentration: 12800 nM
Beside the measured number, compound 4's estimate is 1.4-fold (0.16 log units) above it; the measured number falls inside the stated range.
By their numbers in this assay, from the lowest: compounds 4, 1, 3 and 2 (each within the scatter of the next).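

Moving the chlorine from one position of the phenyl ring to another gives a 1.4-fold lower number from compound 3 to compound 4 (0.16 log units; within the scatter) in this assay, so on this evidence the chlorine's position on the phenyl ring makes no readable difference to the number. Compound 4 also stays close to the two compounds with other rings at this carbon, with a 1.5-fold lower number from compound 2 to compound 4 (0.17 log units; within the scatter) and a 1.1-fold lower number from compound 1 to compound 4 (0.06 log units; within the scatter), which means that all four aromatic groups at this carbon remain indistinguishable. Nothing measured here explains this flat result.

As far as these compounds go, all four groups at this carbon are aromatic rings, so it remains open whether an amine, a carboxylic acid or a longer chain there would move the number beyond the scatter. From the compounds shown here alone, the 5-chlorofuran-2-yl and thiophen-2-yl groups are the same in all four compounds, so what exchanging either would do also remains open.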